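The source may hold more compounds than are shown below. What is called first, only, known or untested is meant among the compounds shown, and "the series" means these compounds.

Measured compounds:
compound 1 `O=S(=O)(/C=C/c1ccc(O)c(O)c1)CCC1CCCC1`, giving 6800 nM in a functional assay, read by fluorescence and spectrophotometry, with a stated time of 1 h; on this read-out lower numbers stand for an effect already at smaller amounts and higher numbers for an effect only at larger amounts of compound;
compound 2 `CCCCCCCS(=O)(=O)/C=C/c1ccc(O)c(O)c1`, giving 7100 nM;
compound 3 `CCCCCCCCS(=O)(=O)/C=C/c1ccc(O)c(O)c1`, giving 6400 nM.

The three values lie within the scatter of one another, so none can be set apart. Compound 4 `O=S(=O)(/C=C/c1ccc(O)c(O)c1)CCCC1CCCC1` has not been measured. It differs from compound 3 by cyclopentyl in place of pentyl on a saturated chain carbon, three bonds along the chain from a sulfonyl sulfur. The same kind of change was made from compound 2 to compound 1, namely (cyclopentyl in place of pentyl on a saturated chain carbon, two bonds along the chain from a sulfonyl sulfur); the two places differ in that one is two bonds along the chain from a sulfonyl sulfur and the other three bonds along. The two cores differ by methyl in place of hydrogen on a saturated chain carbon, seven bonds along the chain from a sulfonyl sulfur. The measured instance gave a 1.0-fold lower number from compound 2 to compound 1 (0.02 log units; within the scatter). Because a 1.0-fold lower number from compound 2 to compound 1 (0.02 log units; within the scatter) lay within the scatter, the step in this assay is expected to be a 1.1-fold higher number from compound 3 to compound 4 (0.03 log units; within the scatter). Compound 4 is therefore estimated at 6800 nM, between 3400 nM and 13000 nM.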

Compound 4, half-maximal effective concentration: 6300 nM
Estimate against measurement, compound 4: 1.1-fold (0.03 log units) above; the range from low to high includes it.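

In this assay, cyclopentyl in place of pentyl left the number within the scatter on both cores, so the change carried over as a step of no measurable size: the same change on two cores in this assay, a 1.0-fold lower number (0.02 log units; within the scatter) from compound 2 to compound 1 and a 1.0-fold lower number (0.01 log units; within the scatter) from compound 3 to compound 4, 1.0-fold (0.01 log units) apart, within the scatter of two such steps The remaining steps agree, with a 1.0-fold lower number from compound 3 to compound 4 (0.01 log units; within the scatter), a 1.1-fold lower number from compound 2 to compound 4 (0.05 log units; within the scatter) and a 1.1-fold lower number from compound 1 to compound 4 (0.03 log units; within the scatter). For the compounds shown here, this shows only that the two cores agree in showing no measurable step, not that a change with a measurable effect would carry from one core to the other, and it gives no ranking of these chains.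

As far as these compounds go, it remains open whether a cyclohexyl ring, or a chain ending in an amine or a carboxylic acid, would move the number. Also open, from the compounds shown here alone, is what methoxy groups in place of the two hydroxyl groups on the shared core would do.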